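This account rests on a few compounds, and the source may have more. Where it says the series, first, only, none or still open, it means among the compounds named here.

Compounds measured so far:
- compound 1 `CNC(=O)[C@@H]1C[C@H](N2CCc3c(ncnc3OCCC3CC3)C2)CN1C(=O)c1ccc(CN)c(OC)c1`: 6 nM
- compound 2 `COc1cc(C(=O)N2C[C@@H](n3cc(C4CC4)nn3)C[C@H]2C(=O)N[C@H]2C[C@@H]2c2ccccc2)ccc1CN`: 960 nM
- compound 3 `COc1cc(C(=O)N2C[C@@H](n3cc(C4CC4)nn3)C[C@H]2C(=O)N[C@H]2CCCC[C@@H]2c2ccccc2)ccc1CN`: 19 nM

In an assay on isolated protein for inhibition of serine protease 1 (Homo sapiens), read by fluorescence (a lower number here means a stronger inhibitor, a higher number a weaker inhibitor), compound 2 stands highest of the three numbers shown, with compound 3 nearest and compound 1 furthest below it. Compound 4 `COc1cc(C(=O)N2C[C@@H](n3cc(C4CC4)nn3)C[C@H]2C(=O)N2CC[C@H](c3ccccc3)C2)ccc1CN` differs from compound 2 in one place: 3-phenylpyrrolidin-1-yl in place of (2-phenylcyclopropyl)amino on a carbonyl carbon. Among the compounds with values here, the one measured step that bears on this is a 51-fold lower number from compound 2 to compound 3 (1.70 log units; beyond the scatter), where a larger ring also replaced the 2-phenylcyclopropyl group and the number fell sharply. Compound 4 changes the same part, but the ring now carries the nitrogen itself and the amide hydrogen is gone, so the earlier step is only a loose guide. A downward step is therefore expected, smaller than that of compound 3 and uncertain in size; compound 4 is estimated at 250 nM (range 60 nM to 1000 nM), which would mean a 3.8-fold lower number from compound 2 to compound 4 (0.58 log units; beyond the scatter).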

Compound 4, half-maximal inhibitory concentration: 220 nM
The estimate for compound 4 lay 1.1-fold (0.06 log units) above the measured number; the range from low to high includes it.
By their numbers in this assay, from the lowest: compound 1; then compound 3; then compound 4; then compound 2.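

Replacing (2-phenylcyclopropyl)amino with 3-phenylpyrrolidin-1-yl gives a 4.4-fold lower number from compound 2 to compound 4 (0.64 log units; beyond the scatter) in this assay, so a lower number at this position does not depend on keeping the amide hydrogen. The drop is smaller than with the 2-phenylcyclohexyl group: compound 3 gives 19 nM, while compound 4 gives 220 nM. No measured evidence here explains either change.

Still open, as far as these compounds go, is whether the phenyl ring is needed at all, as plain pyrrolidin-1-yl would test. Also open, from the compounds shown here alone, is whether 3-phenylpiperidin-1-yl, with its larger ring, would bring the number closer to that of compound 3.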